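The source may hold more compounds than are shown below. What is called first, only, known or untested is meant among the compounds shown, and "the series" means these compounds.

Three compounds share one core and differ mainly in the group attached to the sulfonyl sulfur of the ring sulfonamide. In an ADME assay on MT4 cells (Homo sapiens) for cytotoxicity, read by MTT assay (on this read-out lower numbers stand for higher toxicity in this test and higher numbers for lower toxicity in this test), compound 1 `Cc1cc(/C=C/C#N)cc(C)c1Oc1ccnc(Nc2ccc(CN3CCCN(S(=O)(=O)C(C)C)CC3)cc2)n1` gives 4640 nM. Compound 2 `Cc1cc(C#N)cc(C)c1Oc1ccnc(Nc2ccc(CN3CCCN(S(=O)(=O)N(C)C)CC3)cc2)n1`, which carries a plain nitrile and a dimethylsulfamoyl group, gives 4190 nM in this assay. Compound 3 `Cc1cc(/C=C/C#N)cc(C)c1Oc1ccnc(Nc2ccc(CN3CCCN(S(C)(=O)=O)CC3)cc2)n1`, with a methylsulfonyl group, gives 17400 nM in this assay and stands highest of the three, its gaps to compound 1 and to compound 2 both lying beyond the usual scatter. Going by the values given here, the only directly readable step is a 3.8-fold higher number from compound 1 to compound 3 (0.57 log units; beyond the scatter). Compound 4 `Cc1cc(/C=C/C#N)cc(C)c1Oc1ccnc(Nc2ccc(CN3CCCN(S(=O)(=O)N(C)C)CC3)cc2)n1` has not yet been measured; it differs from compound 3 in one place: dimethylamino in place of methyl on a sulfonyl sulfur. That measured step shows a larger group on this sulfur going with a lower number, and compound 2, which already carries the dimethylsulfamoyl group, gives 4190 nM in this assay. A modest step of a 2.9-fold lower number from compound 3 to compound 4 (0.46 log units; beyond the scatter) toward a lower number is therefore expected. Compound 4 is estimated at 6000 nM in this assay, with a range from 2500 nM to 15000 nM.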

Compound 4, half-maximal cytotoxic concentration: 3900 nM
For compound 4 the middle estimate is 1.5-fold (0.19 log units) above the measured one, and the stated range covers the measured number.
By their numbers in this assay, from the lowest: compounds 4, 2 and 1 (each within the scatter of the next); then compound 3.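

In this assay, going by these compounds alone, the change from methyl to dimethylamino on the sulfonyl sulfur gives a clear drop (a 4.5-fold lower number from compound 3 to compound 4 (0.65 log units; beyond the scatter)), so isopropyl is no longer the only group seen to go with a lower number than methyl on this core. Dimethylamino and isopropyl cannot be told apart (a 1.2-fold lower number from compound 1 to compound 4 (0.08 log units; within the scatter)), and with dimethylamino on the sulfur, 2-cyanoethenyl in place of cyano on an aromatic carbon also leaves the number within the scatter (a 1.1-fold lower number from compound 2 to compound 4 (0.03 log units; within the scatter)). Nothing available here explains why methyl stands apart from these groups.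

Going by these compounds, whether an ethyl group or a phenyl ring on this sulfur would side with compound 3 or with compound 4 remains open. So does whether methyl would keep its high number alongside the plain nitrile of compound 2.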